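Series notes: chain substituent removed, compound 2 to compound 3

This account rests on a few compounds, and the source may have more. Where it says the series, first, only, none or still open, it means among the compounds named here.

Measured so far:
compound 1 `COC(=O)[C@H](CC(C)C)NC(=O)C(=O)c1ccccc1NC(C)=O` gives 72 nM in an assay on mitochondria from liver for inhibition of Amine oxidase [flavin-containing] A (Rattus norvegicus), with a stated time of 60 min; a higher number here means a weaker inhibitor, a lower number a stronger inhibitor
compound 2 `COC(=O)C[C@H](NC(=O)C(=O)c1ccccc1NC(C)=O)C(=O)OC` gives 58 nM in this assay

Compound 2 holds the lower of the two numbers, but the step of a 1.2-fold lower number from compound 1 to compound 2 (0.09 log units; within the scatter) falls within the scatter, so the two compounds are not separated. Compound 3 `COC(=O)CCNC(=O)C(=O)c1ccccc1NC(C)=O` differs from compound 2 by hydrogen in place of methoxycarbonyl on a saturated chain carbon bound to an amide-type nitrogen and a saturated chain carbon. Among the measured compounds shown here, only one measured step touches this region of the shared core: the exchange of one group for another on the same chain carbon, a 1.2-fold lower number from compound 1 to compound 2 (0.09 log units; within the scatter), which is within the scatter. That step swapped substituents; it does not measure removal of the substituent altogether, so the present step is less supported. Given the flat result from compound 1 to compound 2, no step beyond the scatter is expected, with some allowance for a weaker number. Compound 3 is therefore estimated at 85 nM in this assay, expected range 30 nM to 250 nM. The expected step is a 1.5-fold higher number from compound 2 to compound 3 (0.17 log units; within the scatter).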

Compound 3, half-maximal inhibitory concentration: 33 nM
For compound 3 the middle estimate is 2.6-fold (0.41 log units) above the measured one; the range from low to high includes it.
By their numbers in this assay, from the lowest: compounds 3, 2 and 1 (each within the scatter of the next, the first and the last beyond it).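

With the substituent gone altogether, a 1.8-fold lower number from compound 2 to compound 3 (0.24 log units; within the scatter) in this assay, so this step, unlike the earlier exchange of isopropyl for methoxycarbonyl, tests the position with hydrogen alone on the chain carbon. Losing the methoxycarbonyl, with its 4 heavy atoms and 2 hydrogen-bond acceptors, leaves compound 3 within the scatter of compound 2, so these compounds show no need for a substituent at this position in this assay. No measurement at hand bears on the reason for this result.

The compounds shown leave open whether a carboxylic acid, an amine or a longer chain on this same carbon would stay within the scatter. They also leave open what happens if the methoxycarbonyl that compound 3 still carries on its chain is replaced.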